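A few compounds are considered here, and "the series" means these few. Any claim that something is new, unique, unknown or untested is made for them only; others in the source may bear on it.

Working notes on the series. Compound 3 `O=C1N[C@H]2[C@H](CS[C@H]2CCCCCc2cn(Cc3cccc(F)c3)nn2)N1` has, in an assay on isolated protein for inhibition of biotin--protein ligase (Homo sapiens), read by scintillation counting, with a stated time of 10 min (a lower number here means a stronger inhibitor, a higher number a weaker inhibitor), only a limit to show: > 16000 nM. Compound 1 `O=C1N[C@H]2[C@H](CS[C@H]2CCCCCc2cn(Cc3ccccc3Br)nn2)N1` likewise reaches only a limit in this assay, > 16000 nM. Compound 2 `O=C1N[C@H]2[C@H](CS[C@H]2CCCCCc2cn(Cc3ccc(I)cc3)nn2)N1` also stops at a limit in this assay, > 16000 nM. The three steps among them, a step that the two limits leave unreadable from compound 1 to compound 2, a step that the two limits leave unreadable from compound 1 to compound 3 and a step that the two limits leave unreadable from compound 2 to compound 3, are therefore all unreadable in size, since (the limit of > 16000 nM in this assay, at which 3 of the 3 values shown sit). Compound 4 `O=C1N[C@H]2[C@H](CS[C@H]2CCCCCc2cn(Cc3cccc(Cl)c3)nn2)N1` differs from compound 3 by chloro in place of fluoro on an aromatic carbon. Going by the values given here, no measured step reads on this change, and every value so far sits at the limit. The expected step is a step that the limit leaves unreadable from compound 3 to compound 4, nothing beyond the scatter. Compound 4 is therefore estimated at 20000 nM in this assay, within 8000 nM to 60000 nM, most likely reported again only as a limit.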

Compound 4, inhibition constant: > 16000 nM
Compound 4 ended at the assay's limit (the forecaster's own chance of this, stated with the estimate: 80%); the middle value does not contradict the limit.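

Going by these compounds alone, no step from compound 4 to compound 1, compound 2 or compound 3 can be read in size, because all four stop at the same limit: the limit of > 16000 nM in this assay, at which 4 of the 4 values shown sit. The compounds shown leave open how any of these halogen changes alters the inhibition constant in this assay.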